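The compounds below may be only part of what the source reports. "The series", "measured", "known", "first", "only" and "open" are said of these compounds alone.

Measured so far:
compound 1, `O=C(Nc1cccc(C(=O)O/N=C2\CCCc3onc(-c4ccccc4F)c32)c1)c1cccc(F)c1`, in a functional assay on HCC1954 cells (Homo sapiens) for antiproliferative activity, read by MTT assay, with a stated time of 72 h (on this read-out lower numbers stand for stronger inhibition and higher numbers for weaker inhibition), gives > 25000 nM, a limit of the assay rather than a number.
compound 2, `CC1(C)C/C(=N\OC(=O)c2cccc(NC(=O)c3cccc(F)c3)c2)c2c(-c3ccc(F)cc3)noc2C1`, in this assay gives > 25000 nM, again a limit and not a number.

Compound 2 therefore stands where every value shown stands: the limit of > 25000 nM in this assay, at which 2 of the 2 values shown sit. Nothing shown separates compound 2 from compound 1 beyond the fact that neither reached a measurable potency.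

Compound 3, `CC1(C)C/C(=N\OC(=O)c2cccc(NC(=O)c3cccc(F)c3)c2)c2c(-c3cccc(F)c3)noc2C1`, has the same atoms as compound 2 joined differently: 3-fluorophenyl in place of 4-fluorophenyl on an aromatic carbon. Among the compounds with values here, no step between two measured compounds is available, so the size of such a change cannot be read from any measured pair. Since both measured compounds sit at the limit, the expected outcome is no movement beyond the scatter, and most likely another limit. The estimated step is a step that the limit leaves unreadable from compound 2 to compound 3. Compound 3 is expected at 30000 nM, with a range from 12000 nM to 100000 nM.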

Compound 3, half-maximal inhibitory concentration: > 25000 nM
Compound 3: a limit, no number; the forecaster's own chance of this, stated with the estimate: 85%; the middle value does not contradict the limit.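

Compound 3 gives > 25000 nM, a limit and not a number, and no size can be read for the step from compound 2 to compound 3. Still open is how far these compounds lie from a measurable potency in this assay, and how they would rank: the limit of > 25000 nM in this assay, at which 3 of the 3 values shown sit.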